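The source may report more compounds than this note shows. Statements on the series, on what has been measured and on what is new or still open speak of the compounds shown alone.

Going by the values given here, measured in a functional assay on ileum (Cavia porcellus) for antagonist activity (on this read-out higher numbers stand for weaker inhibition and lower numbers for stronger inhibition), compound 1 `Cc1ccc(CCCCOc2ccc3c(O)c([N+](=O)[O-])c(=O)oc3c2)cc1` gives 2500 nM as the only actual number so far. Compound 2 `COC(=O)c1ccc(OCCCOc2ccc3c(O)c([N+](=O)[O-])c(=O)oc3c2)cc1` reads > 10000 nM and that is a limit of the assay, not a number. Compound 3 `Cc1ccc(OCCCOc2ccc3c(O)c([N+](=O)[O-])c(=O)oc3c2)cc1` differs from compound 1 in one place: 4-methylphenoxy in place of 4-methylbenzyl on a saturated chain carbon, three bonds along the chain from an oxygen on an aromatic ring with 4-methylphenoxy in place of 4-methylbenzyl on a saturated chain carbon. Among the compounds with values here, no measured pair shows this swap yet, so in this assay only a small shift is expected, within the usual scatter and leaning towards weaker inhibition. The estimated step of a 1.4-fold higher number from compound 1 to compound 3 (0.15 log units; within the scatter) is therefore modest. Compound 3 is expected at 3500 nM within a range of 1000 nM to 10000 nM for now.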

Compound 3, half-maximal inhibitory concentration: 4500 nM
For compound 3 the middle estimate is 1.3-fold (0.11 log units) below the measured one; measured number inside the range.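

In this assay the swap gives a 1.8-fold higher number from compound 1 to compound 3 (0.26 log units; within the scatter), so compound 1 and compound 3 cannot be told apart, and this chain position accepts 4-methylphenoxy in place of 4-methylbenzyl. Compound 3 also pairs with compound 2, and methyl in place of methoxycarbonyl on an aromatic carbon gives an at least 2.2-fold lower number from compound 2 to compound 3 (0.34 log units; beyond the scatter). Compound 2 stands at a limit of the assay, not at a number: the limit of > 10000 nM in this assay, at which 1 of the 3 values shown sits.

On these data alone, what a carboxylic acid or an amine would do in place of that methyl stays open. As far as these compounds go, the effect of a longer chain also remains open.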